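The source may report more compounds than this note shows. Statements on the series, on what has been measured and on what is new or still open speak of the compounds shown alone.

Measured in a functional assay on NCI-H661 cells (Homo sapiens) for antiproliferative activity, read by MTT assay, with a stated time of 72 h; a lower number here means a stronger inhibitor, a higher number a weaker inhibitor:
Compound 1 `O=C(CCCCCCc1nc(-c2ccccc2)no1)C(F)(F)F`: 520 nM
Compound 2 `Cc1ccc(-c2noc(CCCCCCC(=O)C(F)(F)F)n2)cc1`: 18700 nM
Compound 3 `O=C(CCCCCCc1nc(-c2ccc(F)cc2)no1)C(F)(F)F`: 12700 nM

Compound 1 is the strongest inhibitor of the three, and the other two lie far from it: a 36-fold higher number from compound 1 to compound 2 (1.56 log units; beyond the scatter) and a 24-fold higher number from compound 1 to compound 3 (1.39 log units; beyond the scatter). Compound 3 therefore belongs to the weaker pair, and the two members of that pair cannot be told apart: a 1.5-fold lower number from compound 2 to compound 3 (0.17 log units; within the scatter).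

Compound 4 `O=C(CCCCCCc1nc(-c2ccc([N+](=O)[O-])cc2)no1)C(F)(F)F` keeps the rest of compound 3 and changes one group, with nitro in place of fluoro on an aromatic carbon, para to a large group (nitro in place of fluoro on an aromatic carbon).

Among the measured compounds shown here, the closest precedent is the swap of one group for another at that carbon, a 1.5-fold lower number from compound 2 to compound 3 (0.17 log units; within the scatter). The two large steps replaced hydrogen, which is not the case here. For the measured compounds named here, no nitro compound has been measured, so this remains a wide guess. The expected change is none beyond the scatter: a 1.1-fold lower number from compound 3 to compound 4 (0.02 log units; within the scatter), as estimated. For compound 4 the expected value is 12000 nM, with an estimated range of 3000 nM to 40000 nM.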

Compound 4, half-maximal inhibitory concentration: 17500 nM
Compound 4: middle estimate off by 1.5-fold (0.16 log units), on the low side, and the stated range covers the measured number.
By their numbers in this assay, from the lowest: compound 1; then compounds 3, 4 and 2 (each within the scatter of the next).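

In this assay, nitro on this aromatic carbon, para to a large group, gives a result that cannot be separated from those of the two earlier substituted compounds: a 1.4-fold higher number from compound 3 to compound 4 (0.14 log units; within the scatter), and a 1.1-fold lower number from compound 2 to compound 4 (0.03 log units; within the scatter). The large gap from the unsubstituted compound also reappears with this third group, a 34-fold higher number from compound 1 to compound 4 (1.53 log units; beyond the scatter), so among the compounds shown, fluoro, methyl and nitro all fall on the weak side, and moving from the one heavy atom of fluoro to the three of nitro adds no change beyond the scatter. No supporting measurement is available to explain why these three groups sit so far from hydrogen.

An amine or a carboxylic acid on this carbon could test whether every replacement of hydrogen here falls with these three, or whether some group stays close to compound 1 at 520 nM. The same groups on the other carbons of this ring also remain open, since every substituted compound shown carries its group at this one place.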